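Compound 4: open aminobutyl chain replacing the piperidinyl group

The source may report more compounds than this note shows. Statements on the series, on what has been measured and on what is new or still open speak of the compounds shown alone.

In an ADME assay on the whole organism (strain FVB) for pharmacokinetics, with Mus musculus as the target, read by LC-MS, at a dose of 30 mg/kg by the oral route (a higher number here means more compound in the circulation at the dose given, a lower number less compound in the circulation), compound 1 (`NCCOc1ccc([C@H]2CC[C@]3(CC2)OOC2(O3)C3CC4CC(C3)CC2C4)cc1`) gives 287 nM, compound 2 (`CC(C)(O)CNCCCOc1ccc([C@H]2CC[C@]3(CC2)OOC2(O3)C3CC4CC(C3)CC2C4)cc1`) gives 1210 nM and compound 3 (`c1cc([C@H]2CC[C@]3(CC2)OOC2(O3)C3CC4CC(C3)CC2C4)ccc1OC1CCNCC1`) gives 810 nM. Compound 3 stands level with compound 2 within the scatter, as a 1.5-fold lower number from compound 2 to compound 3 (0.17 log units; within the scatter) shows, and clear of compound 1, as a 2.8-fold higher number from compound 1 to compound 3 (0.45 log units; beyond the scatter) shows.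

Compound 4 (`NCCCCOc1ccc([C@H]2CC[C@]3(CC2)OOC2(O3)C3CC4CC(C3)CC2C4)cc1`) carries 4-aminobutyl in place of piperidin-4-yl on an oxygen on an aromatic ring.

For the measured compounds named here, the nearest precedent is compound 1, which carries 2-aminoethyl at that place, and the modest 2.8-fold higher number from compound 1 to compound 3 (0.45 log units; beyond the scatter) suggests a lower number on leaving the piperidin-4-yl group. Compound 2 goes against any rule that ringless chains fall short, and a 4.2-fold higher number from compound 1 to compound 2 (0.62 log units; beyond the scatter) is also modest. Going by the values given here, no measured pair isolates chain length, so the expectation is weak. A modest fall is expected, with the estimated change being a 2.1-fold lower number from compound 3 to compound 4 (0.33 log units; beyond the scatter). For compound 4 the estimate is 380 nM, with an expected range of 140 nM to 1000 nM.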

Compound 4, maximal plasma concentration: 370 nM
Compound 4: the middle estimate sits 1.0-fold (0.01 log units) above what was measured; the range from low to high includes it.
By their numbers in this assay, from the lowest: compounds 1 and 4 (each within the scatter of the next); then compounds 3 and 2 (each within the scatter of the next).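

In this assay, for the compounds shown here, replacing piperidin-4-yl with 4-aminobutyl on the oxygen gives the first measured ring-to-chain change with a similar chain length (a 2.2-fold lower number from compound 3 to compound 4 (0.34 log units; beyond the scatter)), and the ring goes with the higher number here. Among the two chains ending in plain amino, 4-aminobutyl and 2-aminoethyl stand level (a 1.3-fold higher number from compound 1 to compound 4 (0.11 log units; within the scatter)), so longer chain length alone gives no gain across this pair. The plain amino end of compound 4 also falls short of the (2-hydroxy-2-methylpropyl)amino end of compound 2 (a 3.3-fold lower number from compound 2 to compound 4 (0.51 log units; beyond the scatter)), and compound 2 shows that a ringless chain can still reach the level of compound 3.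

Still open, going by these compounds, is whether a pyrrolidin-3-yl group on the same oxygen would keep the number of compound 3. The data on hand offer no explanation for any of these steps.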